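The compounds below may be only part of what the source reports. "The series", "measured", "known", "first", "only" and "open" are said of these compounds alone.

For the measured compounds named here, compound 2 (`CC1=C(/C=C/C(=O)/C=C/c2cccc(C(F)(F)F)c2)C(C)(C)CCC1O`) gives 2600 nM in a functional assay on PCa 2b cells (Homo sapiens) for cytotoxicity, read by MTT assay, with a stated time of 72 h (on this read-out higher numbers stand for weaker inhibition and lower numbers for stronger inhibition), the lowest of the two numbers measured so far; its nearest neighbour is compound 1 (`CC1=C(/C=C/C(=O)/C=C/c2ccccc2)C(C)(C)CCC1O`), which gives 12600 nM in the same assay. Compound 3 (`CC1=C(/C=C/C(=O)/C=C/c2cc(C(F)(F)F)cc(C(F)(F)F)c2)C(C)(C)CCC1O`) differs from compound 2 in one place: trifluoromethyl in place of hydrogen on an aromatic carbon. Going by the values given here, the only measured step that bears on this change is a 4.8-fold lower number from compound 1 to compound 2 (0.69 log units; beyond the scatter), the same exchange of hydrogen for trifluoromethyl on the aromatic ring. That step was modest but lay beyond the scatter, and a second trifluoromethyl on the same ring is expected to move the number in the same direction, though there is no evidence here that the gain repeats in full. A step of a 2.0-fold lower number from compound 2 to compound 3 (0.30 log units; within the scatter) is therefore expected. Compound 3 is estimated at 1300 nM, with a likely range from 450 nM to 4000 nM.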

Compound 3, half-maximal inhibitory concentration: 3500 nM
Compound 3: middle estimate off by 2.7-fold (0.43 log units), on the low side, within the range that was stated.
By their numbers in this assay, from the lowest: compounds 2 and 3 (each within the scatter of the next); then compound 1.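

In this assay the second trifluoromethyl, on an aromatic carbon meta to a trifluoromethyl group, gives a 1.3-fold higher number from compound 2 to compound 3 (0.13 log units; within the scatter) and so does not repeat the gain of the first exchange, which gave a 4.8-fold lower number from compound 1 to compound 2 (0.69 log units; beyond the scatter) on the same ring. The same exchange of hydrogen for trifluoromethyl thus has two outcomes on this ring, one beyond the scatter and one within it, and compound 2 and compound 3 cannot be told apart on this read-out. Nothing given here accounts for the difference between these two steps.

Still open, from the compounds shown here alone, is whether a group of another kind at this place, such as an amine, a nitrile or a carboxylic acid, would give a lower number than compound 2 does at 2600 nM in this assay. Going by these compounds, it is also open whether a single trifluoromethyl at this place, with hydrogen at the other, would behave as in compound 2.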